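Swapping Methoxy for Chloro in Three Growth Inhibitors

A few compounds are considered here, and "the series" means these few. Any claim that something is new, unique, unknown or untested is made for them only; others in the source may bear on it.

Three compounds were measured in a functional assay on NCI-H460 cells (Homo sapiens) for inhibition; on this read-out lower numbers stand for stronger inhibition of growth and higher numbers for weaker inhibition of growth:
compound 1, `COc1cc(/C=C/C(=O)c2cccc(-n3cc(-c4ccc(Cl)cc4)[nH]c3=O)c2)cc(OC)c1OC`, 3740 nM
compound 2, `COc1ccc(-c2cn(-c3cccc(C(=O)/C=C/c4ccc(O)c(OC)c4)c3)c(=O)[nH]2)cc1`, 3230 nM
compound 3, `COc1ccc(-c2cn(-c3cccc(C(=O)/C=C/c4cc(OC)c(OC)c(OC)c4)c3)c(=O)[nH]2)cc1`, 1560 nM

The change from compound 3 to compound 1 is chloro in place of methoxy on an aromatic carbon; in this assay it made a 2.4-fold higher number from compound 3 to compound 1 (0.38 log units; beyond the scatter). The cores of compound 2 and compound 3 differ as 4-hydroxy-3-methoxyphenyl in place of 3,4,5-trimethoxyphenyl on a double-bonded chain carbon bound to a double-bonded chain carbon, and a 2.1-fold lower number from compound 2 to compound 3 (0.32 log units; beyond the scatter). Compound 1 and compound 2 lie within the scatter of each other. The unmeasured compound 4, `COc1cc(/C=C/C(=O)c2cccc(-n3cc(-c4ccc(Cl)cc4)[nH]c3=O)c2)ccc1O`, arises from compound 2 by chloro in place of methoxy on an aromatic carbon, the same change as from compound 3 to compound 1, at a place described in identical words. For the measured compounds named here, a step of a 2.1-fold higher number from compound 2 to compound 4 (0.32 log units; beyond the scatter) is expected, resting on a single precedent because a 2.4-fold higher number from compound 3 to compound 1 (0.38 log units; beyond the scatter) is the only instance of this change measured here. Compound 4 is therefore estimated at 6800 nM in this assay, with a range from 3200 nM to 15000 nM expected.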

Compound 4, concentration for 50% growth inhibition: 3900 nM
For compound 4 the middle estimate is 1.7-fold (0.24 log units) above the measured one, within the range that was stated.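

In this assay the change from 4-methoxyphenyl to 4-chlorophenyl gave a 1.2-fold higher number from compound 2 to compound 4 (0.08 log units; within the scatter) on the core of compound 2, so on that core the change left the read-out within the scatter. For the compounds shown here, with only two pairs, the change can be said to carry over from one core to the other only in the sense that its steps stay within the scatter of each other; this does not show that it reliably gives a higher number on any core. The two steps cannot be told apart: the same change on two cores in this assay, a 2.4-fold higher number (0.38 log units; beyond the scatter) from compound 3 to compound 1 and a 1.2-fold higher number (0.08 log units; within the scatter) from compound 2 to compound 4, 2.0-fold (0.30 log units) apart, within the scatter of two such steps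

The compounds shown leave open whether other groups at this place, such as fluoro, trifluoromethyl or an amine, would give steps of similar size. They also leave open whether the step would hold on a core carrying a carboxylic acid on its double-bonded chain.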